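This account rests on a few compounds, and the source may have more. Where it says the series, first, only, none or still open, it means among the compounds named here.

Measured compounds:
compound 1 `COc1cccc(/C=C/C(=O)c2c(OC)cc(OC)cc2OC)c1`: 1800 nM
compound 2 `COc1cc(OC)c(C(=O)/C=C/c2ccc(Cl)cc2)c(OC)c1`: 970 nM
compound 3 `COc1cc(OC)c(C(=O)/C=C/c2c(F)cccc2F)c(OC)c1`: 1290 nM

In a functional assay for inhibition, with Homo sapiens as the target (on this read-out higher numbers stand for weaker inhibition and lower numbers for stronger inhibition), compound 2 stands level with the other two compounds within the scatter, as a 1.9-fold lower number from compound 1 to compound 2 (0.27 log units; within the scatter) and a 1.3-fold higher number from compound 2 to compound 3 (0.12 log units; within the scatter) show. Compound 4 `COc1cc(OC)c(C(=O)/C=C/c2ccc([N+](=O)[O-])cc2)c(OC)c1` has nitro in place of chloro on an aromatic carbon, para to a large group (nitro in place of chloro on an aromatic carbon). For the measured compounds named here, no measured step tests this exchange directly. The closest evidence comes from the three exchanges of the substituted phenyl group, which include a 1.4-fold lower number from compound 1 to compound 3 (0.14 log units; within the scatter) and the two steps above. All three are small, so no step beyond the scatter is expected in this assay. The expected change is a 1.0-fold higher number from compound 2 to compound 4 (0.01 log units; within the scatter). For compound 4 the estimated value is 1000 nM, with an expected range of 400 nM to 2500 nM.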

Compound 4, half-maximal inhibitory concentration: 407 nM
Estimate against measurement, compound 4: 2.5-fold (0.39 log units) above; the measured number falls inside the stated range.
By their numbers in this assay, from the lowest: compound 4; then compounds 2, 3 and 1 (each within the scatter of the next).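

Nitro in place of chloro on an aromatic carbon, para to a large group, gives a 2.4-fold lower number from compound 2 to compound 4 (0.38 log units; beyond the scatter) in this assay, the only step among these compounds that lies beyond the scatter. The three earlier exchanges of the whole substituted phenyl group all stayed within the scatter, so this position does respond to a change of a single substituent, though only modestly. Nothing shown here gives a reason for this step. From the compounds shown here alone, whether an amine or a nitrile at the same place would shift the number in the same direction remains open.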